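The source may report more compounds than this note shows. Statements on the series, on what has been measured and on what is new or still open speak of the compounds shown alone.

Measured in a functional assay on KYSE-450 cells (Homo sapiens) for inhibition, read by MTT assay, with a stated time of 48 h; on this read-out higher numbers stand for weaker inhibition and lower numbers for stronger inhibition:
- compound 1 `C/C=C/C(=O)N(Cc1ccc(OC)c([N+](=O)[O-])c1)c1cc(OC)c(OC)c(OC)c1`: 510 nM
- compound 2 `COc1ccc(CN(C(=O)C=C(C)C)c2cc(OC)c(OC)c(OC)c2)cc1O`: 280 nM
- compound 3 `COC(=O)c1cc(CNc2cc(OC)c(OC)c(OC)c2)ccc1OC`: 41100 nM

Compound 2, at 280 nM, lies within the scatter of compound 1, at 510 nM, so these two cannot be ranked. The gap from compound 2 to compound 3 is beyond the scatter, with compound 3 carrying the much higher number.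

The next compound to be tested in this assay is compound 4 `COc1ccc(CN(C(=O)CO)c2cc(OC)c(OC)c(OC)c2)cc1O`. Relative to compound 2, hydroxymethyl stands in place of 2-methylprop-1-en-1-yl on a carbonyl carbon: hydroxymethyl in place of 2-methylprop-1-en-1-yl on a carbonyl carbon. The rest of the structure is unchanged.

Going by the values given here, no measured pair isolates this change, so the expectation is loose. Compound 3, at 41100 nM, has no such amide, but it also differs elsewhere, so it offers only a weak hint that this part of the structure matters. A moderate move towards a higher number, meaning weaker inhibition, is expected, beyond the scatter but far short of the level of compound 3. The estimated change is a 5.4-fold higher number from compound 2 to compound 4 (0.73 log units; beyond the scatter). For compound 4 the expected value is 1500 nM, with an estimated range of 300 nM to 9000 nM.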

Compound 4, half-maximal inhibitory concentration: 370 nM
Beside the measured number, compound 4's estimate is 4.1-fold (0.61 log units) above it, and the stated range covers the measured number.
By their numbers in this assay, from the lowest: compounds 2, 4 and 1 (each within the scatter of the next); then compound 3.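

In this assay, going by these compounds alone, this is the first pair that isolates the group on the carbonyl carbon, and hydroxymethyl in place of 2-methylprop-1-en-1-yl gives a 1.3-fold higher number from compound 2 to compound 4 (0.12 log units; within the scatter). The two groups differ substantially in what is counted: 2-methylprop-1-en-1-yl has 4 heavy atoms, all carbon, a double bond, and no hydrogen-bond donor or acceptor, whereas hydroxymethyl has 2 heavy atoms, one of them oxygen, with 1 hydrogen-bond donor and 1 hydrogen-bond acceptor, yet this step does not separate compound 2 from compound 4. At this position, therefore, neither the double bond nor the larger carbon chain is required to keep the number in the range of compound 2, and no available measurement explains this result.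

From the compounds shown here alone, with only these two groups compared directly on this core, it remains open whether the position is equally undemanding for an aminomethyl group, a carboxylic acid, or a longer chain ending in hydroxyl. Also open is whether the carbonyl itself matters, as no pair shown changes that alone on an otherwise unchanged structure.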